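Series notes: methyl in place of amino, compound 1 to compound 4

The source may hold more compounds than are shown below. What is called first, only, known or untested is meant among the compounds shown, and "the series" means these compounds.

Measured compounds:
- compound 1 `Nc1ccc2c(c1)OCCCN2S(=O)(=O)c1ccc(-c2cnc(C3CC3)o2)cc1`: 56 nM
- compound 2 `O=S(=O)(c1ccc(-c2cnc(C3CC3)o2)cc1)N1CCCCc2ccccc21`: 38 nM
- compound 3 `O=S(=O)(c1ccc(-c2cnc(C3CC3)o2)cc1)N1CCCOc2ccc(Cl)cc21`: 19 nM

In a functional assay on SK-OV-3 cells (Homo sapiens) for antiproliferative activity, read by MTT assay, with a stated time of 72 h (on this read-out higher numbers stand for weaker inhibition and lower numbers for stronger inhibition), compound 1 gives the highest of the three numbers. Against compound 2 the gap is within the scatter, so no order between the two is claimed; compound 3 sits beyond the scatter at a lower number. Compound 4 `Cc1ccc2c(c1)OCCCN2S(=O)(=O)c1ccc(-c2cnc(C3CC3)o2)cc1` is not yet measured. It differs from compound 1 as follows: methyl in place of amino on an aromatic carbon. Among the compounds with values here, no pair differing in one place has been measured, so the size of the step is not known from the data. The expected step of a 1.6-fold lower number from compound 1 to compound 4 (0.20 log units; within the scatter) is small, toward a lower number, and likely within the scatter, in line with compound 3 at 19 nM carrying no donor on that ring. Compound 4 is estimated at 35 nM, range 12 nM to 100 nM.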

Compound 4, half-maximal inhibitory concentration: 179 nM
For compound 4 the middle estimate is 5.1-fold (0.71 log units) below the measured one; the whole stated range lies below it.
By their numbers in this assay, from the lowest: compounds 3, 2 and 1 (each within the scatter of the next, the first and the last beyond it); then compound 4.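

In this assay, within the data shown here, methyl in place of amino on an aromatic carbon gives a 3.2-fold higher number from compound 1 to compound 4 (0.50 log units; beyond the scatter), the first step read at a single place. This position, meta to a fused ring and para to a fused ring, is therefore not indifferent to its group, and here the amino gives the lower number. Nothing measured on these compounds accounts for the step. Open, as far as these compounds go, is how a hydroxyl, a methoxy or an acetamido group at this place would compare with amino and methyl. Also open, from the compounds shown here alone, is whether the same exchange gives a similar step on other cores.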